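The compounds below may be only part of what the source reports. "The series", "measured", "known", "first", "only" and "open" are said of these compounds alone.

Measured in a functional assay on SW-620 cells (Homo sapiens) for cytotoxicity, read by colorimetric assay; a higher number here means a weaker inhibitor, a lower number a stronger inhibitor:

- Compound 1 `O=C(/C=C/c1ccc(CN2C(=O)/C(=C3\Nc4ccccc4\C3=N/O)c3cc(Cl)ccc32)cc1)NO`: 80 nM
- Compound 2 `Cc1ccc2c(c1)/C(=C1/Nc3ccccc3/C1=N\O)C(=O)N2Cc1ccc(/C=C/C(=O)NO)cc1`: 50 nM
- Compound 3 `COc1ccc2c(c1)/C(=C1/Nc3ccccc3/C1=N\O)C(=O)N2Cc1ccc(/C=C/C(=O)NO)cc1`: 40 nM

In this series, compound 3, at 40 nM, stands within the scatter of both other compounds, so the data set no order among the three. Compound 4 `O=C(/C=C/c1ccc(CN2C(=O)/C(=C3\Nc4ccccc4\C3=N/O)c3cc(Br)ccc32)cc1)NO` carries bromo in place of methoxy on an aromatic carbon.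

Within the data shown here, two measured steps bear on this change. One is a 2.0-fold lower number from compound 1 to compound 3 (0.30 log units; within the scatter), with methoxy in place of chloro. The other is a 1.3-fold lower number from compound 2 to compound 3 (0.10 log units; within the scatter), with methoxy in place of methyl. Neither goes beyond the scatter, and a 1.6-fold lower number from compound 1 to compound 2 (0.20 log units; within the scatter) does not either. Among the measured compounds shown here, no bromo compound has been measured. Chloro is the nearest measured group, and compound 1, which carries it, gives 80 nM. No step beyond the scatter is therefore expected in this assay, though a small drift toward that number is possible.

The estimated change is a 1.8-fold higher number from compound 3 to compound 4 (0.24 log units; within the scatter). For compound 4 the expected value is 70 nM, with an estimated range of 35 nM to 140 nM.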

Compound 4, half-maximal inhibitory concentration: 60 nM
Compound 4: middle estimate off by 1.2-fold (0.07 log units), on the high side, within the range that was stated.
By their numbers in this assay, from the lowest: compounds 3, 2, 4 and 1 (each within the scatter of the next).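

In this assay bromo on this aromatic carbon can now be set against each of the other three groups: against methoxy (a 1.5-fold higher number from compound 3 to compound 4 (0.18 log units; within the scatter)), against methyl (a 1.2-fold higher number from compound 2 to compound 4 (0.08 log units; within the scatter)) and against chloro (a 1.3-fold lower number from compound 1 to compound 4 (0.12 log units; within the scatter)). Every pair among the four compounds therefore lies within the scatter, so a second halogen adds no separation, and this position has so far taken chloro, bromo, methyl and methoxy without a step beyond it. Nothing in hand offers a reason for this flat reading.

From the compounds shown here alone, whether any group here could move the number beyond the scatter remains open, for instance an amine, a carboxylic acid or a nitro group. Going by these compounds, all four compounds differ on this one carbon only, and what changes elsewhere in the shared core would do stays open as well.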